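A few compounds are considered here, and "the series" means these few. Any claim that something is new, unique, unknown or untested is made for them only; others in the source may bear on it.

Of the compounds shown here, three sharing one core have been measured in a functional assay on L1210 cells (Mus musculus), with a stated time of 12 days; on this read-out higher numbers stand for higher potency (the scale is a negative logarithm) and lower numbers for lower potency. Compound 1 `CC1=C(N2CC2)C(=O)C(CC(C)OC(N)=O)=C(N2CC2)C1=O` gives 5.79 in this assay, compound 2 `CC1=C(N2CC2)C(=O)C(C(C)C)=C(N2CC2)C1=O` gives 5.21, and compound 3 `CCCC1=C(N2CC2)C(=O)C(CCC)=C(N2CC2)C1=O` gives 4.44. Among these three numbers compound 2 stands second highest, with compound 1 beyond the scatter above it and compound 3 beyond the scatter below it. For the measured compounds named here, the only single-site step measured so far is a number 0.58 log units lower from compound 1 to compound 2 (beyond the scatter), where a small all-carbon group replaced a larger group that carried nitrogen and oxygen.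

Compound 4 `CC1=C(N2CC2)C(=O)C(N2CC2)=C(N2CC2)C1=O` differs from compound 2 by aziridin-1-yl in place of isopropyl on a double-bonded ring carbon. Going by the values given here, no measured step removes an isopropyl or brings in an aziridin-1-yl, so the guidance is indirect. A modest gain is expected because a number 0.58 log units lower from compound 1 to compound 2 (beyond the scatter) followed the departure of a group holding hydrogen-bond acceptors, and the entering aziridin-1-yl brings one hydrogen-bond acceptor back to the same kind of position. Compound 4 is therefore estimated at about 5.5, within a range from 4.9 to 6.1. That estimate implies an expected step of a number 0.29 log units higher from compound 2 to compound 4 (within the scatter).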

Compound 4, logarithm of the reciprocal of the active concentration, log(1/C): 6.21
Estimate against measurement, compound 4: 0.71 log units below; measured number outside the range, above it.
By their numbers in this assay, from the lowest: compound 3; then compound 2; then compound 1; then compound 4.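

In this assay, putting aziridin-1-yl in place of isopropyl on a double-bonded ring carbon leaves the count at 3 heavy atoms yet gives a number 1.00 log units higher from compound 2 to compound 4 (beyond the scatter), so the heavy-atom count of the group alone does not set the number at this position. Group size does not rank these compounds either: the smaller isopropyl goes with a number 0.58 log units lower from compound 1 to compound 2 (beyond the scatter), whereas the equally small aziridin-1-yl goes with a number 0.42 log units higher from compound 1 to compound 4 (beyond the scatter). Nothing available explains why this change raises the number.

The compounds shown leave open whether the rise goes with the ring nitrogen or with the three-membered ring. A cyclopropyl group, which has the ring without the nitrogen, and a dimethylamino group, which has the nitrogen without the ring, would separate the two at this position.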